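Chloro to dimethylamino: expected effect in this series

The compounds below may be only part of what the source reports. "The series", "measured", "known", "first", "only" and "open" are said of these compounds alone.

Compound 1: `COc1ccc(C(=O)c2cc(/C=C/C(=O)NO)n(C)c2)cc1`, in an assay on isolated protein with histone deacetylase HD2 (Zea mays) as the target (a lower number here means a stronger inhibitor, a higher number a weaker inhibitor), compound 1 gives 1740 nM
Compound 2: `Cn1cc(C(=O)c2ccc(Cl)cc2)cc1/C=C/C(=O)NO`, in this assay compound 2 gives 1450 nM

For the measured compounds named here, compound 2 stands lowest of the two numbers measured so far in this assay; its nearest neighbour is compound 1, and the step of a 1.2-fold lower number from compound 1 to compound 2 (0.08 log units; within the scatter) is within the scatter, so no order between the two can be claimed. Compound 3 is `CN(C)c1ccc(C(=O)c2cc(/C=C/C(=O)NO)n(C)c2)cc1`. It differs from compound 2 by dimethylamino in place of chloro on an aromatic carbon, on an aromatic carbon of a six-membered aromatic ring of carbon only, para to a large group. Going by the values given here, the only measured step at this position is a 1.2-fold lower number from compound 1 to compound 2 (0.08 log units; within the scatter), which stayed within the scatter; no measured step involves dimethylamino. On that basis no change beyond the scatter is expected for compound 3 in this assay. For compound 3 the expected step is a 1.2-fold higher number from compound 2 to compound 3 (0.07 log units; within the scatter). Compound 3 is estimated at 1700 nM, within the range 700 nM to 4200 nM.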

Compound 3, inhibition constant: 1450 nM
For compound 3 the middle estimate is 1.2-fold (0.07 log units) above the measured one; low and high end bracket the measured number.
By their numbers in this assay, from the lowest: compounds 2, 3 and 1 (each within the scatter of the next).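

Dimethylamino brings 3 heavy atoms and 1 hydrogen-bond acceptor where chloro has 1 heavy atom and no acceptor, yet this assay shows no change at the digits printed from compound 2 to compound 3 (within the scatter) and a 1.2-fold lower number from compound 1 to compound 3 (0.08 log units; within the scatter) for this exchange on the aromatic carbon para to a large group. The position has now carried methoxy, chloro and dimethylamino, and no order can be claimed among compound 1, compound 2 and compound 3. No supporting measurement bears on why these numbers lie so close together.

On these data alone, whether a carboxylic acid, a primary amine or a longer alkyl chain at this position would give a step beyond the scatter remains open. Also open, as far as these compounds go, is whether these three groups would read alike against another target.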